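This account rests on a few compounds, and the source may have more. Where it says the series, first, only, none or still open, it means among the compounds named here.

Compounds measured so far: compound 1 `COc1cc(-c2cc(/C=C/C(=O)c3ccc(N)cc3)[nH]n2)cc(OC)c1OC` gives 87% in a functional assay on Hs-578T cells (Homo sapiens) for cytotoxicity, read by sulforhodamine B assay, with a stated time of 48 h, tested at 1 uM; on this read-out lower numbers stand for a stronger effect and higher numbers for a weaker effect at the one concentration tested; compound 2 `COc1ccc(-c2cc(/C=C/C(=O)c3ccc(OC)c(OC)c3)[nH]n2)cc1` gives 81%; compound 3 `COc1cc(-c2cc(/C=C/C(=O)c3ccc(Cl)c(Cl)c3)[nH]n2)cc(OC)c1OC` gives 104%.

Compound 1 stands second highest of the three numbers. Going by the values given here, compound 2 lies within the usual scatter of it, and the one single-point step measured so far is a number 17 percentage points higher from compound 1 to compound 3 (beyond the scatter). Compound 4 `COc1ccc(-c2cc(/C=C/C(=O)c3ccc(N)cc3)[nH]n2)cc1OC` differs from compound 1 by hydrogen in place of methoxy on an aromatic carbon. That measured step concerns the group on a carbonyl carbon, a different part of the molecule, and so does not bear directly on removing a methoxy. Compound 1 and compound 2 differ in more than one place, so their closeness gives only weak guidance. No step beyond the scatter is therefore expected in this assay. Compound 4 is estimated at 88%, with a range from 70% to 105%. The expected step is thus a number 1 percentage points higher from compound 1 to compound 4 (within the scatter).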

Compound 4, a percentage reported as activity, at one concentration (the size of the read-out at that concentration, not a potency): 96%
Estimate against measurement, compound 4: 8 percentage points below, and the stated range covers the measured number.
By their numbers in this assay, from the lowest: compounds 2, 1, 4 and 3 (each within the scatter of the next, the first and the last beyond it).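

In this assay, hydrogen in place of methoxy on this aromatic carbon gives a number 9 percentage points higher from compound 1 to compound 4 (within the scatter) as the first step read at this part of the molecule. At the one concentration tested, this methoxy, ortho to a methoxy group, can therefore go without a step beyond the scatter. Nothing at hand offers an explanation for this result. The compounds shown leave open whether a hydroxyl, a fluorine atom or an ethoxy group on this carbon would differ from compound 1 beyond the scatter, and whether removing the other methoxy groups would do so.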